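Methoxyphenyl change on the sulfonyl sulfur: working notes

A few compounds are considered here, and "the series" means these few. Any claim that something is new, unique, unknown or untested is made for them only; others in the source may bear on it.

Measured in a functional assay on HCT-116 cells (Homo sapiens) for cytotoxicity; on this read-out lower numbers stand for an effect already at smaller amounts and higher numbers for an effect only at larger amounts of compound:
- compound 1 `CC(=O)SCC(=O)c1ccc(NS(=O)(=O)c2ccc(OC(F)(F)F)cc2)cc1`: 8800 nM
- compound 2 `CC(=O)SCC(=O)c1ccc(NS(=O)(=O)c2ccc(C)cc2)cc1`: 6500 nM
- compound 3 `COc1cccc(S(=O)(=O)Nc2ccc(C(=O)CSC(C)=O)cc2)c1`: 2600 nM

Of the three, compound 3 has the lowest number, at 2600 nM, and its gaps to compound 1 and compound 2 both lie beyond the scatter. The next compound to be measured is compound 4 `COc1ccc(S(=O)(=O)Nc2ccc(C(=O)CSC(C)=O)cc2)cc1`, which has 4-methoxyphenyl in place of 3-methoxyphenyl on a sulfonyl sulfur.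

Going by the values given here, two measured steps bear on this change. The closer one is a 2.5-fold lower number from compound 2 to compound 3 (0.40 log units; beyond the scatter), with 3-methoxyphenyl in place of 4-methylphenyl on a sulfonyl sulfur. The other is a 1.4-fold lower number from compound 1 to compound 2 (0.13 log units; within the scatter), with methyl in place of trifluoromethoxy on an aromatic carbon. Neither step isolates the change from 3-methoxyphenyl to 4-methoxyphenyl, so any expectation here is loose. Compound 4 shares its 4-substituted phenyl naming with compound 2, whose value of 6500 nM sits above that of compound 3. A modest step towards a higher number is therefore expected, of similar or smaller size than a 2.5-fold lower number from compound 2 to compound 3 (0.40 log units; beyond the scatter). The estimated change is a 1.7-fold higher number from compound 3 to compound 4 (0.24 log units; within the scatter). The estimate for compound 4 is 4500 nM, with an expected range of 2000 nM to 9500 nM.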

Compound 4, half-maximal effective concentration: 500 nM
For compound 4 the middle estimate is 9.0-fold (0.95 log units) above the measured one; the measured number lies below the stated range.
By their numbers in this assay, from the lowest: compound 4; then compound 3; then compounds 2 and 1 (each within the scatter of the next).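

In this assay, moving the methoxy group with no change in atoms gives a 5.2-fold lower number from compound 3 to compound 4 (0.72 log units; beyond the scatter), so at this place on the sulfonyl sulfur the result depends on how the methoxyphenyl group is substituted and not only on which atoms it carries. The substituent on the 4-substituted phenyl also matters: methoxy in place of methyl gives a 13-fold lower number from compound 2 to compound 4 (1.11 log units; beyond the scatter), and methyl in place of trifluoromethyl on the oxygen gives an 18-fold lower number from compound 1 to compound 4 (1.25 log units; beyond the scatter), whereas the step between compound 1 and compound 2 stayed within the scatter. Compound 2 had suggested that 4-substitution goes with a higher number than the 3-methoxyphenyl group of compound 3, but compound 4 goes against this, so the effect of placement cannot be separated from the identity of the group.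

The compounds shown leave open whether ethoxy, a hydroxyl or an amine in place of the methoxy of compound 4 would hold or lower this number. Nothing in hand accounts for the gain seen with the 4-methoxyphenyl group.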